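Naphthalenesulfonamide series: substituent at the fused ring, nitro next

The source may hold more compounds than are shown below. What is called first, only, known or untested is meant among the compounds shown, and "the series" means these compounds.

Measured so far in an assay on isolated protein for inhibition of Neuropeptide Y receptor type 5 (Homo sapiens); on this read-out lower numbers stand for stronger inhibition and higher numbers for weaker inhibition:
compound 1, `COc1ccc2c(c1)CC(NCC1CCN(CCNS(=O)(=O)c3cccc4ccccc34)CC1)CCC2`, 45 nM
compound 2, `O=S(=O)(NCCN1CCC(CNC2CCCc3ccc(Cl)cc3C2)CC1)c1cccc2ccccc12`, 85 nM
compound 3, `Cc1ccc2c(c1)CC(NCC1CCN(CCNS(=O)(=O)c3cccc4ccccc34)CC1)CCC2`, 72 nM

All three share the same core and differ only in the group on the six-membered carbon ring of the fused system. In this assay compound 3 lies with its number between those of compound 1 and compound 2, and both of its steps are within the scatter: a 1.6-fold higher number from compound 1 to compound 3 (0.20 log units; within the scatter) and a 1.2-fold lower number from compound 2 to compound 3 (0.07 log units; within the scatter). The remaining pair is also flat, a 1.9-fold higher number from compound 1 to compound 2 (0.28 log units; within the scatter), so methoxy, chloro and methyl at this position have not separated from each other.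

The next compound is compound 4, `O=[N+]([O-])c1ccc2c(c1)CC(NCC1CCN(CCNS(=O)(=O)c3cccc4ccccc34)CC1)CCC2`. It differs from compound 3 in one place: nitro in place of methyl on an aromatic carbon. Each of the three measured steps bears on this change, since each swaps one group for another at the same aromatic carbon, and none of them moved the number beyond the scatter. Nitro has not been tried here, so there is nothing to indicate a departure from that picture, and the expectation is a step of about a 1.4-fold higher number from compound 3 to compound 4 (0.14 log units; within the scatter), that is none beyond the scatter, with some room on the weaker side. For compound 4 the estimate in this assay is 100 nM, with a range from 40 nM to 250 nM.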

Compound 4, half-maximal inhibitory concentration: 79 nM
The estimate for compound 4 lay 1.3-fold (0.10 log units) above the measured number; low and high end bracket the measured number.
By their numbers in this assay, from the lowest: compounds 1, 3, 4 and 2 (each within the scatter of the next).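

In this assay nitro joins methoxy, chloro and methyl as a fourth group at this aromatic carbon that does not separate from the others: a 1.1-fold higher number from compound 3 to compound 4 (0.04 log units; within the scatter), a 1.1-fold lower number from compound 2 to compound 4 (0.03 log units; within the scatter) and a 1.8-fold higher number from compound 1 to compound 4 (0.24 log units; within the scatter). What is new is that the flat picture survives a swap that differs more in the computed counts than a change of one heavy atom for another, since nitro brings three heavy atoms and two hydrogen-bond acceptors where methyl has one heavy atom and no hydrogen-bond acceptors, so neither count has yet gone with a step beyond the scatter at this position. Nothing on hand offers an explanation for this flatness.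

From the compounds shown here alone, it remains open whether an amine, a carboxylic acid or a phenyl ring at this aromatic carbon would move the number beyond the scatter, or whether these would stay with the four groups seen so far. Also open, going by these compounds, is where the core stands with plain hydrogen at this carbon, which would show whether any of the four groups matters at all in this read-out.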